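The source may hold more compounds than are shown below. What is called first, only, known or untested is meant among the compounds shown, and "the series" means these compounds.

Going by the values given here, compound 2 `O=C1/C(=C/c2ccccc2Br)CCc2cc(O)ccc21` gives 20000 nM in an ADME assay on MCF7 cells for inhibition of cytochrome P450 26A1 (Homo sapiens) (on this read-out lower numbers stand for stronger inhibition and higher numbers for weaker inhibition), and stands at the higher of the two numbers so far; compound 1 `COc1ccc2c(c1)CC/C(=C\c1ccccc1Br)C2=O` gives 9000 nM, and the step of a 2.2-fold higher number from compound 1 to compound 2 (0.35 log units; beyond the scatter) comes from a hydrogen in place of a methyl on an oxygen on an aromatic ring. Compound 3 `O=C1/C(=C/c2ccccc2-c2ccccc2)CCc2cc(O)ccc21` differs from compound 2 by phenyl in place of bromo on an aromatic carbon. Among the compounds with values here, no measured step touches this position, and the step from compound 1 to compound 2 does not bear on it, so the step of no change at the digits printed from compound 2 to compound 3 (within the scatter) is expected to stay within the scatter. Compound 3 is accordingly estimated at 20000 nM, within 6000 nM to 70000 nM.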

Compound 3, half-maximal inhibitory concentration: 20000 nM
Estimate against measurement, compound 3: no gap at the digits printed; low and high end bracket the measured number.
By their numbers in this assay, from the lowest: compound 1; then compounds 2 and 3 (each within the scatter of the next).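

With no change at the digits printed from compound 2 to compound 3 (within the scatter), the aromatic carbon that carried bromo in compound 2 is shown to accept phenyl in this assay, although six heavy atoms and a whole aromatic ring enter where one atom left. The earlier compounds shown here varied only the oxygen substituent and did not touch this position. Nothing shown offers a reason for this result. Still open, as far as these compounds go, is how an amine or a carboxylic acid on this carbon would read, and whether phenyl would behave alike with the methyl on the oxygen, as in compound 1.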